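Triazole sulfonamides: shifting a halogen around the phenyl ring

A few compounds are considered here, and "the series" means these few. Any claim that something is new, unique, unknown or untested is made for them only; others in the source may bear on it.

Measured compounds:
- compound 1, `Cc1ccccc1-n1cc(-c2ccccc2NS(=O)(=O)c2c[nH]c(=O)[nH]c2=O)nn1`: 6550 nM
- compound 2, `Cc1ccc(-n2cc(-c3ccccc3NS(=O)(=O)c3c[nH]c(=O)[nH]c3=O)nn2)cc1`: 2190 nM
- compound 3, `O=c1[nH]cc(S(=O)(=O)Nc2ccccc2-c2cn(-c3ccccc3F)nn2)c(=O)[nH]1`: 15300 nM

These three share one core and differ only in the group attached to an aromatic nitrogen of the triazole ring. In a functional assay on OVCAR-3 cells (Homo sapiens) for antiproliferative activity, read by MTT assay, with a stated time of 24 h (a higher number here means a weaker inhibitor, a lower number a stronger inhibitor), compound 3 gives the highest number of the three, so it is the weakest inhibitor in this set; its nearest neighbour is compound 1 and the furthest is compound 2, and both gaps were judged beyond the scatter.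

Compound 4, `O=c1[nH]cc(S(=O)(=O)Nc2ccccc2-c2cn(-c3cccc(Cl)c3)nn2)c(=O)[nH]1`, is not yet measured. The change is 3-chlorophenyl in place of 2-fluorophenyl on an aromatic nitrogen. Two earlier steps bear on it. Moving a methyl from the 2-position to the 4-position gave a 3.0-fold lower number from compound 1 to compound 2 (0.48 log units; beyond the scatter), while replacing that methyl with fluoro at the 2-position gave a 2.3-fold higher number from compound 1 to compound 3 (0.37 log units; beyond the scatter). The largest step, a 7.0-fold higher number from compound 2 to compound 3 (0.84 log units; beyond the scatter), combined a change of group and of position. Going from compound 3 to compound 4 again changes both the halogen and its place on the ring, and the measured steps suggest that a substituent away from the 2-position tends toward a lower number. A modest decrease is therefore expected, a 3.1-fold lower number from compound 3 to compound 4 (0.49 log units; beyond the scatter). The estimate for compound 4 in this assay is 5000 nM, within a range from 1500 nM to 15000 nM.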

Compound 4, half-maximal inhibitory concentration: 2180 nM
Beside the measured number, compound 4's estimate is 2.3-fold (0.36 log units) above it; measured number inside the range.
By their numbers in this assay, from the lowest: compounds 4 and 2 (each within the scatter of the next); then compound 1; then compound 3.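

In this assay the swap of 2-fluorophenyl for 3-chlorophenyl gives a 7.0-fold lower number from compound 3 to compound 4 (0.85 log units; beyond the scatter) and brings a halogen-bearing ring level with the best methyl-bearing ring, since the comparison with 4-methylphenyl shows a 1.0-fold lower number from compound 2 to compound 4 (0.00 log units; within the scatter) and so the two groups cannot be told apart here. Against 2-methylphenyl the same group gives a 3.0-fold lower number from compound 1 to compound 4 (0.48 log units; beyond the scatter) and completes a split that no compound in this set goes against: compound 1 and compound 3, with 2-methylphenyl and 2-fluorophenyl, both give higher numbers than compound 2 and compound 4, with 4-methylphenyl and 3-chlorophenyl, so a methyl is not needed for a low number at this position. No measurement offered here gives a reason for these differences.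

Because the halogen and its place on the ring change together between compound 3 and compound 4, the set leaves open which of the two carries the step, a question that 2-chlorophenyl or 3-fluorophenyl would help to settle. Also open, on these data alone, is how this position responds to a phenyl ring bearing an amine or a carboxylic acid, or to a longer chain in place of the phenyl ring.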